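A few compounds are considered here, and "the series" means these few. Any claim that something is new, unique, unknown or untested is made for them only; others in the source may bear on it.

In a functional assay on MCF7 cells (Homo sapiens) for cytotoxicity, read by fluorescence, with a stated time of 72 h (on this read-out higher numbers stand for weaker inhibition and lower numbers for stronger inhibition), compound 3 (`CC(C)c1n[nH]c2c(NCc3ccc(-c4ccccn4)cc3)nc(N[C@H]3CC[C@H](N)CC3)nc12`) gives 474 nM, the weakest of the three measured compounds, against compound 1 (`CC(C)c1n[nH]c2c(NCc3ccc(-c4ccccn4)cc3)nc(NCCN)nc12`) at 62 nM and compound 2 (`CC(C)c1n[nH]c2c(NCc3ccc(-c4ccccn4)cc3)nc(N3CCNCC3)nc12`) at 21 nM. Compound 4 (`COc1ccc(CNc2nc(NCc3ccc(-c4ccccn4)cc3)c3[nH]nc(C(C)C)c3n2)cc1`) carries 4-methoxybenzyl in place of 4-aminocyclohexyl on a nitrogen on an aromatic ring. Changes at this same group have already moved the number, with a 3.0-fold lower number from compound 1 to compound 2 (0.47 log units; beyond the scatter), a 7.6-fold higher number from compound 1 to compound 3 (0.88 log units; beyond the scatter) and a 23-fold higher number from compound 2 to compound 3 (1.35 log units; beyond the scatter). For the measured compounds named here, no measured compound carries the entering group, which has no hydrogen-bond donor, so these steps give only a scale. A modest rise in this assay is expected, and the estimated step is a 2.5-fold higher number from compound 3 to compound 4 (0.40 log units; beyond the scatter). Compound 4 is expected at 1200 nM, with an estimated range from 250 nM to 6000 nM.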

Compound 4, half-maximal inhibitory concentration: 5300 nM
Compound 4: middle estimate off by 4.4-fold (0.65 log units), on the low side, and the stated range covers the measured number.
By their numbers in this assay, from the lowest: compound 2; then compound 1; then compound 3; then compound 4.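

Among the four compounds, the side chain of compound 4 is the only one with no hydrogen-bond donor, and in this assay the change gives an 11-fold higher number from compound 3 to compound 4 (1.05 log units; beyond the scatter). That makes this the highest number at this position, with an 85-fold higher number from compound 1 to compound 4 (1.93 log units; beyond the scatter) and a 250-fold higher number from compound 2 to compound 4 (2.40 log units; beyond the scatter), so the position's range extends well beyond what the amine-bearing groups showed. No supporting evidence explains this rise. The compounds shown do not separate loss of the amine from arrival of the aromatic ring. A plain cyclohexyl or a 4-aminobenzyl group would separate them.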